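The source may report more compounds than this note shows. Statements on the series, on what has been measured and on what is new or still open speak of the compounds shown alone.

Working notes on the series. Compound 1 `N#CC1=C(N)Oc2c(c3nc4ccccc4nc3c3ccccc23)C12C(=O)N(Cc1cnnn1-c1cccc(Cl)c1)c1ccccc12` and compound 2 `N#CC1=C(N)Oc2c(N)cc3nc4ccccc4nc3c2C12C(=O)N(Cc1cnnn1-c1cccc(C(F)(F)F)c1)c1ccccc12` share the same core and differ at more than one place, so only their two values can be compared. In an ADME assay on HUVEC cells (Homo sapiens) for antiproliferative activity, read by MTT assay, with a stated time of 48 h (on this read-out lower numbers stand for stronger inhibition and higher numbers for weaker inhibition), compound 1 gives > 50000 nM, which is a limit of the assay and not a number. Compound 2 also reaches only a limit in this assay, > 50000 nM. Both values sit at the limit of > 50000 nM in this assay, at which 2 of the 2 values shown sit, so compound 2 stands at the limit alongside compound 1, with no order between them. Compound 3 `N#CC1=C(N)Oc2c(N)cc3nc4ccccc4nc3c2C12C(=O)N(Cc1cnnn1-c1ccc(Cl)cc1Cl)c1ccccc12` is not yet measured and differs from compound 2 by 2,4-dichlorophenyl in place of 3-(trifluoromethyl)phenyl on an aromatic nitrogen. Among the compounds with values here, no step between measured compounds is available to size this change. The step that the limit leaves unreadable from compound 2 to compound 3 is expected to be none beyond the usual scatter, because compound 2 already sits at the limit of > 50000 nM in this assay, at which 2 of the 2 values shown sit. Compound 3 is therefore expected to come out at 60000 nM, within 20000 nM to 200000 nM, most likely reported again as a limit.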

Compound 3, half-maximal inhibitory concentration: > 50000 nM
Compound 3 gave a limit, no number (the forecaster's own chance of this, stated with the estimate: 80%); the middle value does not contradict the limit.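

Within the data shown here, compound 3, like compound 2, reaches only a limit in this assay, so no step between them can be read: the limit of > 50000 nM in this assay, at which 3 of the 3 values shown sit. The compounds shown leave open how far each lies from that limit and whether any change on the shared core gives a readable value.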